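A few compounds are considered here, and "the series" means these few. Any claim that something is new, unique, unknown or untested is made for them only; others in the source may bear on it.

Compound 1, with the structure `O=C(CSC(=S)N[C@H]1CCOC1=O)Nc1ccc(C(=O)/C=C/c2ccccc2)cc1`, reaches only a limit in a functional assay on SMMC-7721 cells (Homo sapiens) for cytotoxicity, read by MTT assay, with a stated time of 72 h (a lower number here means a stronger inhibitor, a higher number a weaker inhibitor), where compound 1 gives > 128000 nM. Compound 2, with the structure `O=C(CSC(=S)N[C@H]1CCOC1=O)Nc1ccc(C(=O)/C=C/c2ccccc2Cl)cc1`, gives in this assay a value of 20400 nM. For the measured compounds named here, the step of an at least 6.2-fold lower number from compound 1 to compound 2 (0.79 log units; beyond the scatter) is the one measured change, and compound 2 holds the only number in this assay, the other value being a limit (the limit of > 128000 nM in this assay, at which 1 of the 2 values shown sits). Compound 3 has the structure `O=C(CSC(=S)N[C@H]1CCOC1=O)Nc1ccc(C(=O)/C=C/c2ccc([N+](=O)[O-])cc2)cc1`, differing from compound 2 by 4-nitrophenyl in place of 2-chlorophenyl on a double-bonded chain carbon bound to a double-bonded chain carbon. The measured step bears on it only in part: it shows that a substituent on that ring moves the number, but the group and its place both change here, so the direction is not fixed. A number close to that of compound 2 is therefore expected, with a wide range, the expected step being a 1.5-fold higher number from compound 2 to compound 3 (0.17 log units; within the scatter). Compound 3 is estimated at 30000 nM, between 8000 nM and 120000 nM.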

Compound 3, half-maximal inhibitory concentration: > 128000 nM
Compound 3 ended at the assay's limit; the forecaster's own chance of this, stated with the estimate: 20%; at least 4.2-fold (0.63 log units) between middle value and limit.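

In this assay the change to 4-nitrophenyl gives an at least 6.2-fold higher number from compound 2 to compound 3 (0.79 log units; beyond the scatter), so a substituent on this ring does not by itself yield a measurable number. Compound 3 stands, as compound 1 does, at a limit and not at a number: the limit of > 128000 nM in this assay, at which 2 of the 3 values shown sit. The step from compound 1 to compound 3 cannot be read, both values being limits.

The group and its place change together in the step to compound 3, so the compounds shown leave open whether the chloro group itself or its place on the ring goes with the number of compound 2. Also open, on these data alone, is how an amine, a methoxy group or a carboxylic acid on that ring would read in this assay.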